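This account rests on a few compounds, and the source may have more. Where it says the series, first, only, none or still open, it means among the compounds named here.

Measured compounds:
- compound 1, `COc1cccc(-n2cc3nc(-c4cccnc4C)n(C[C@H]4CCCN(Cc5ccco5)C4)c(=O)c3n2)c1`: 2.7 nM
- compound 2, `COc1cccc(-n2cc3nc(-c4cccnc4C)n(C[C@H]4CCCN(CC5CCO5)C4)c(=O)c3n2)c1`: 23 nM
- compound 3, `COc1cccc(-n2cc3nc(-c4cccnc4C)n(C[C@H]4CCCN(Cc5cnco5)C4)c(=O)c3n2)c1`: 120 nM

These three compounds share one core and differ only in the group carried by the amine nitrogen of the saturated ring. In an assay on HEK293 cells for displacement of a labelled ligand from growth hormone secretagogue receptor type 1 (Homo sapiens), with a stated time of 60 min (a higher number here means a weaker inhibitor, a lower number a stronger inhibitor), compound 3 gives the highest number of the three, so it is the weakest binder of the set: the step of a 44-fold higher number from compound 1 to compound 3 (1.65 log units; beyond the scatter) is large, and the step of a 5.2-fold higher number from compound 2 to compound 3 (0.72 log units; beyond the scatter) is modest but still clear.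

Compound 4, `COC[C@H](C)N1CCC[C@H](Cn2c(-c3cccnc3C)nc3cn(-c4cccc(OC)c4)nc3c2=O)C1`, has not yet been measured. It differs from compound 3 by 1-(methoxymethyl)ethyl in place of (1,3-oxazol-5-yl)methyl on an amine nitrogen in a ring. Among the compounds with values here, the steps that bear on this change are those in which the same position was varied: an 8.5-fold higher number from compound 1 to compound 2 (0.93 log units; beyond the scatter), where a non-aromatic oxygen-containing ring with a single acceptor replaced the furan, and a 5.2-fold higher number from compound 2 to compound 3 (0.72 log units; beyond the scatter). The incoming group, like oxetan-2-yl, is non-aromatic and carries one acceptor, so compound 4 is expected to land nearer compound 2 than compound 3. The expected step is a 4.0-fold lower number from compound 3 to compound 4 (0.60 log units; beyond the scatter), towards a lower number. Compound 4 is therefore estimated at 30 nM in this assay, with a range from 8 nM to 120 nM.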

Compound 4, half-maximal inhibitory concentration: 1.7 nM
The estimate for compound 4 lay 18-fold (1.25 log units) above the measured number; measured number below the stated range.
By their numbers in this assay, from the lowest: compounds 4 and 1 (each within the scatter of the next); then compound 2; then compound 3.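

In this assay an aromatic ring on the amine nitrogen proves unnecessary for a low number: 1-(methoxymethyl)ethyl has no ring, yet the change gives a 1.6-fold lower number from compound 1 to compound 4 (0.20 log units; within the scatter) and so matches the furan-bearing group. Lacking an aromatic ring does not settle the outcome either, as two non-aromatic groups are separated by a 14-fold lower number from compound 2 to compound 4 (1.13 log units; beyond the scatter) in favour of the open chain. The swap for (1,3-oxazol-5-yl)methyl gives a 71-fold lower number from compound 3 to compound 4 (1.85 log units; beyond the scatter) and is the widest step yet seen at this position, so this site responds strongly to the choice of group.

The data shown give no reason for these differences. Open questions are how much the chain's ether oxygen and its defined stereocentre contribute, which a plain isopropyl group and the opposite stereoisomer would test.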